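This account rests on a few compounds, and the source may have more. Where it says the series, first, only, none or still open, it means among the compounds named here.

Measured so far:
- compound 1 `Cn1nc2c(=O)n(CC3(O)CCN(Cc4ccc(-c5ccco5)cc4Cl)CC3)cnc2c1-c1ccc(CNC(=O)C(F)(F)F)cc1`: 2060 nM
- compound 2 `Cn1nc2c(=O)n(CC3(O)CCN(Cc4ccc(-c5ccco5)cc4Cl)CC3)cnc2c1-c1ccc(CNCCO)cc1`: 8.2 nM

In an assay on isolated protein for inhibition of ubiquitin carboxyl-terminal hydrolase 7 (Homo sapiens), with stated times of 30 min and 2 h (on this read-out higher numbers stand for weaker inhibition and lower numbers for stronger inhibition), compound 2 gives the lowest of the two numbers; its nearest neighbour is compound 1, which sits far higher, with a 250-fold lower number from compound 1 to compound 2 (2.40 log units; beyond the scatter) separating the pair.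

Compound 3 `Cn1nc2c(=O)n(CC3(O)CCN(Cc4ccc(-c5ccco5)cc4Cl)CC3)cnc2c1-c1ccc(C(F)(F)F)cc1` is the next case. The change from compound 2 is trifluoromethyl in place of ((2-hydroxyethyl)amino)methyl on an aromatic carbon. For the measured compounds named here, only one measured step touches this region: the step from compound 1 to compound 2, where the amine nitrogen was changed, gave a 250-fold lower number from compound 1 to compound 2 (2.40 log units; beyond the scatter). Compound 3 takes away that amine nitrogen and its attached chain altogether, so the comparison points the other way, and a large rise in this assay is expected, roughly of the size seen before, a 370-fold higher number from compound 2 to compound 3 (2.56 log units; beyond the scatter). For compound 3 the estimate is 3000 nM, with a range from 500 nM to 20000 nM.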

Compound 3, half-maximal inhibitory concentration: 530 nM
Compound 3: middle estimate off by 5.7-fold (0.75 log units), on the high side, and the stated range covers the measured number.
By their numbers in this assay, from the lowest: compound 2; then compound 3; then compound 1.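

In this assay, the ((2-hydroxyethyl)amino)methyl group at this aromatic carbon clearly outperforms trifluoromethyl, with a 65-fold higher number from compound 2 to compound 3 (1.81 log units; beyond the scatter). The amide-bearing group of compound 1 does worse than trifluoromethyl, with a 3.9-fold lower number from compound 1 to compound 3 (0.59 log units; beyond the scatter), so among these three compounds a chain at this carbon does not help by itself, and the result depends on what the chain carries. No available evidence bears on the reason for this order.

The compounds shown do not separate the contribution of the amine nitrogen from that of the terminal hydroxyl, a question that a plain aminomethyl group or a 2-methoxyethylamino chain could address. From the compounds shown here alone, how a carboxylic acid or a longer hydroxyalkyl chain on that amine would compare also remains open.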